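Anticonvulsant-type screen: swapping the aryl group of compound 2

The source may report more compounds than this note shows. Statements on the series, on what has been measured and on what is new or still open speak of the compounds shown alone.

Compound 2 `CCc1ccc(NC(=O)CCCN2C(=O)c3ccccc3C2=O)cc1` has the highest number of the two compounds measured in a functional assay on the whole organism (strain albino) with Mus musculus as the target, with a stated time of 4 h; on this read-out higher numbers stand for an effect only at larger amounts of compound and lower numbers for an effect already at smaller amounts; compound 2 gives 300 mg/kg. Its nearest neighbour is compound 1 `Cc1ccc(NC(=O)CCCN2C(=O)c3ccccc3C2=O)cc1`, which in this assay gives 100 mg/kg, and the change from compound 1 to compound 2, methyl in place of hydrogen on a saturated chain carbon bound to an aromatic carbon, brought a 3.0-fold higher number from compound 1 to compound 2 (0.48 log units; beyond the scatter). Compound 3 `Cc1cc(Cl)ccc1NC(=O)CCCN1C(=O)c2ccccc2C1=O` differs from compound 2 by 4-chloro-2-methylphenyl in place of 4-ethylphenyl on an amide-type nitrogen. Within the data shown here, no measured step covers this exact swap; the only step known is the one from compound 1 to compound 2, and it shows that the 4-ethylphenyl group now leaving gave a higher number than a smaller group. A modest move to a lower number, or none beyond the scatter, is therefore expected, a 3.0-fold lower number from compound 2 to compound 3 (0.48 log units; beyond the scatter). Compound 3 is estimated at 100 mg/kg, within 30 mg/kg to 300 mg/kg.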

Compound 3, minimum effective dose: 300 mg/kg
Estimate against measurement, compound 3: 3.0-fold (0.48 log units) below; low and high end bracket the measured number.
By their numbers in this assay, from the lowest: compound 1; then compounds 2 and 3 (each within the scatter of the next).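

Swapping 4-ethylphenyl for 4-chloro-2-methylphenyl on the amide-type nitrogen brought no change at the digits printed from compound 2 to compound 3 (within the scatter) in this assay, so two aryl groups that differ in their substituents can give the same reading at this position. Replacing 4-methylphenyl with the same new group gave a 3.0-fold higher number from compound 1 to compound 3 (0.48 log units; beyond the scatter), which means that compound 1 now stands apart from two neighbours and still shows an effect at the smallest amount of the three. Nothing available here explains why the groups on this nitrogen give these readings.

The compounds shown leave open how the chlorine and the methyl of the new group each contribute, since neither a 4-chlorophenyl nor a 2-methylphenyl group appears among them. Also unanswered is how this position would respond to a ring carrying an amine or a carboxylic acid.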